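From formyl to a benzyl ester side chain

This account rests on a few compounds, and the source may have more. Where it says the series, first, only, none or still open, it means among the compounds named here.

In a functional assay on SEM cells (Homo sapiens) for cytotoxicity, with a stated time of 72 h (on this read-out higher numbers stand for an effect only at larger amounts of compound and lower numbers for an effect already at smaller amounts), compound 1 (`C=C[C@@](C)(/C=C/c1ccc(O)cc1)CC/C=C/C(=O)c1ccccc1`) is reported only as a limit (> 36600 nM). Compound 2 (`C=C[C@@](C)(/C=C/c1ccc(O)c(/C=C/c2ccc(Cl)c(Cl)c2)c1)CCC=C(C)C`) is likewise reported only as a limit (> 7500 nM). Among the measured compounds shown here, compound 3 (`COc1ccc(/C=C/[C@@](C)(/C=C/c2ccc(O)c(C=O)c2)CCC=C(C)C)cc1`) gives 4550 nM as the only actual number in the set, so it has no measured neighbour to be ranked against.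

Compound 4 (`COc1ccc(/C=C/[C@@](C)(/C=C/c2ccc(O)c(/C=C/C(=O)OCc3ccccc3)c2)CCC=C(C)C)cc1`) carries 2-(benzyloxycarbonyl)ethenyl in place of formyl on an aromatic carbon, ortho to a hydroxy group (2-(benzyloxycarbonyl)ethenyl in place of formyl on an aromatic carbon). The entering group brings one six-membered aromatic ring of carbon only. For the measured compounds named here, no measured pair in the set shows what a swap of this kind does, so the forecast rests on compound 3 (4550 nM) as its single anchor and is correspondingly loose.

A small expected shift toward effect only at larger amounts (a 1.5-fold higher number from compound 3 to compound 4 (0.19 log units; within the scatter)) is the working assumption, and it may well stay within the usual scatter of this assay rather than beyond it. A report as a limit instead of a number is also a real possibility. For compound 4 the estimated value is 7000 nM (expected range 2500 nM to 18000 nM).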

Compound 4, half-maximal effective concentration: > 36600 nM
Compound 4 gave a limit, no number (the forecaster's own chance of this, stated with the estimate: 40%); middle value at least 5.2-fold (0.71 log units) away from the limit.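

Among the compounds shown here, the swap of formyl for 2-(benzyloxycarbonyl)ethenyl on the aromatic carbon ortho to a hydroxy group gives the first readable step in this assay: an at least 8.0-fold higher number from compound 3 to compound 4 (0.90 log units; beyond the scatter). This place on the shared core is therefore not indifferent to the group it carries: with formyl, compound 3 gives a real number of 4550 nM, while the larger side chain with its six-membered aromatic ring of carbon moves the read-out beyond the scatter, toward effect only at larger amounts of compound. The step can be read only as a lower bound, because compound 4 stands at a limit and not at a number: the limit of > 36600 nM in this assay, at which 2 of the 4 values shown sit.

The compounds shown leave open which part of the entering group goes with this step, whether the ethenyl link, the ester or the benzyl ring, and how far the value of compound 4 lies past its limit. A methyl ester, a carboxylic acid or a plain ethenyl group at this same place, on the core of compound 3, would separate these parts.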